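Nitro for Fluoro at the Cytotoxicity Limit

This account rests on a few compounds, and the source may have more. Where it says the series, first, only, none or still open, it means among the compounds named here.

Compound 1 `Fc1ccc(-c2cn3nc(Cc4ccc(Cl)cc4)sc3n2)cc1` is assessed in a functional assay on HeLa cells (Homo sapiens) for cytotoxicity, with a stated time of 72 h; a lower number here means a stronger inhibitor, a higher number a weaker inhibitor. In this assay compound 1 gives only a limit, > 250000 nM. Compound 2 `Clc1ccc(-c2cn3nc(Cl)sc3n2)cc1` in this assay gives 95000 nM. Compound 3 `COc1ccc(-c2cn3nc(Cl)sc3n2)cc1` returns only a limit in this assay, > 250000 nM. Within the data shown here, the one step between neighbours that differ in a single place is an at least 2.6-fold higher number from compound 2 to compound 3 (0.42 log units; beyond the scatter), so the exchange of one group on that ring moved the number out of the scatter, toward weaker inhibition. The limit deserves note: the limit of > 250000 nM in this assay, at which 2 of the 3 values shown sit.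

The change to compound 4 `O=[N+]([O-])c1ccc(-c2cn3nc(Cc4ccc(Cl)cc4)sc3n2)cc1` is nitro in place of fluoro on an aromatic carbon. Among the measured compounds shown here, no measured step exchanges fluoro for nitro; the step from compound 2 to compound 3 is the only one on the same ring, and it shows that swapping the group there can shift the number by a modest amount. Compound 1 already sits at the limit; a shift of that size would most likely leave compound 4 at the limit as well. Compound 4 is therefore expected to give about 200000 nM in this assay, within 50000 nM to 600000 nM, which as a step means an estimated at least 1.2-fold lower number from compound 1 to compound 4 (0.09 log units; that floor lies within the scatter).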

Compound 4, half-maximal inhibitory concentration: > 250000 nM
Compound 4: no number, only a limit (the forecaster's own chance of this, stated with the estimate: 65%); middle value at least 1.2-fold (0.09 log units) away from the limit.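

Compound 1 and compound 4 each give only a limit in this assay, so the step from compound 1 to compound 4 cannot be read: the limit of > 250000 nM in this assay, at which 3 of the 4 values shown sit. The compounds shown leave open whether nitro in place of fluoro on an aromatic carbon changes the number at all, and by how much.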